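Cytotoxicity notes: pyridinylmethyl in place of bromobenzyl

This account rests on a few compounds, and the source may have more. Where it says the series, first, only, none or still open, it means among the compounds named here.

Within the data shown here, compound 2 `Brc1cccc(Cn2ccc3nc(-c4ccccc4)nc-3c2)c1` is the only member with a number in an ADME assay on MDBK cells (Bos taurus) for cytotoxicity; on this read-out lower numbers stand for higher toxicity in this test and higher numbers for lower toxicity in this test: compound 2 gives 85000 nM. Compound 1 `Clc1cccc(Cn2ccc3nc(-c4ccccc4)nc-3c2)c1` sits at a limit of the assay rather than a number: in this assay compound 1 gives > 100000 nM. Among the measured compounds shown here, the only measured step, an at least 1.1-fold lower number from compound 1 to compound 2 (0.07 log units; that floor lies within the scatter), is a halogen exchange and stays within the scatter. The unmeasured compound 3 `c1ccc(-c2nc3ccn(Cc4ccccn4)cc-3n2)cc1` differs from compound 2 by pyridin-2-yl in place of 3-bromophenyl on a saturated chain carbon bound to an aromatic nitrogen. For the measured compounds named here, no measured step covers an exchange of this kind; the halogen step shows only that a small change on the same ring did not move the read-out beyond the scatter. The expected step in this assay is therefore a 1.2-fold higher number from compound 2 to compound 3 (0.07 log units; within the scatter), none beyond the scatter. Compound 3 is estimated at 100000 nM, within 40000 nM to 250000 nM, with a fair chance that only a limit, as for (the limit of > 100000 nM in this assay, at which 1 of the 2 values shown sits), is reported.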

Compound 3, half-maximal cytotoxic concentration: > 100000 nM
Compound 3 ended at the assay's limit; the forecaster's own chance of this, stated with the estimate: 50%; the middle value lies on the limit itself.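

In this assay, the saturated chain carbon bound to an aromatic nitrogen now takes a change of ring and not only a halogen exchange: pyridin-2-yl in place of 3-bromophenyl gives an at least 1.1-fold higher number from compound 2 to compound 3 (0.07 log units; that floor lies within the scatter). Among these compounds, the entering ring brings one hetero atom and one hydrogen-bond acceptor, neither present in this group in the earlier compounds, and the read-out gives no lower number with them. The step from compound 1 to compound 3 cannot be read, both values being limits, and the limit now holds most of the series: the limit of > 100000 nM in this assay, at which 2 of the 3 values shown sit.

Still open, on these data alone, is whether any group at this place gives a number clearly lower than those seen here, such as a carboxylic acid or an amine on the ring, or a longer chain at the saturated carbon. As far as these compounds go, how far compound 1 and compound 3 lie past the limit also stays unknown.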